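The source may hold more compounds than are shown below. What is called first, only, known or untested is meant among the compounds shown, and "the series" means these compounds.

Series notes. In a functional assay on the whole organism (strain Wistar) for inhibition, with Rattus norvegicus as the target, read by paw edema, with stated times of 30 min and 3 h, at a dose of 20 mg/kg (on this read-out higher numbers stand for more inhibition at the one dose given (going by the name of the read-out) and lower numbers for less inhibition), compound 1 `CCOC(=O)C1=C(C)NC(C)=C(C(=O)OCC)C1c1ccc(OCC(=O)NCc2ccccc2)cc1` gives 31.1%, compound 2 `CCOC(=O)C1=C(C)NC(C)=C(C(=O)OCC)C1c1ccc(OCC(=O)NNC(=O)c2cccs2)cc1` gives 61.1% and compound 3 `CCOC(=O)C1=C(C)NC(C)=C(C(=O)OCC)C1c1ccc(OCC(=O)NNC(=O)c2ccsc2Cl)cc1` gives 53.3%. Compound 3 stands second highest of the three numbers, nearest compound 2 and furthest from compound 1: a number 7.8 percentage points lower from compound 2 to compound 3 (within the scatter), while a number 22.2 percentage points higher from compound 1 to compound 3 (beyond the scatter). Compound 4 `CCOC(=O)C1=C(C)NC(C)=C(C(=O)OCC)C1c1ccc(OCC(=O)NNC(=O)CCC(=O)O)cc1` is not yet measured; it differs from compound 3 by 2-carboxyethyl in place of 2-chlorothiophen-3-yl on a carbonyl carbon. The measured step that bears on it most is the other exchange on the same carbonyl carbon, a number 7.8 percentage points lower from compound 2 to compound 3 (within the scatter), which stayed within the scatter; a number 30 percentage points higher from compound 1 to compound 2 (beyond the scatter) and a number 22.2 percentage points higher from compound 1 to compound 3 (beyond the scatter) alter the group on the amide-type nitrogen instead. Going by the values given here, no measured step exchanges a ring for a chain. A step of a number 8.3 percentage points lower from compound 3 to compound 4 (within the scatter) is therefore expected, tending lower. Compound 4 is estimated at 45%, range 25% to 65%, in this assay.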

Compound 4, a percentage reported as inhibition, in the whole organism at one dose (the size of the read-out at that dose, not a potency): 56.9%
Compound 4: middle estimate off by 11.9 percentage points, on the low side; the range from low to high includes it.
By their numbers in this assay, from the lowest: compound 1; then compounds 3, 4 and 2 (each within the scatter of the next).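

In this assay the carbonyl carbon takes an open chain as readily as a ring: 2-carboxyethyl gives a number 3.6 percentage points higher from compound 3 to compound 4 (within the scatter) and a number 4.2 percentage points lower from compound 2 to compound 4 (within the scatter) when it replaces the two thiophene groups. The rise over the benzyl compound also holds without a ring at this place, with a number 25.8 percentage points higher from compound 1 to compound 4 (beyond the scatter) alongside the steps to the two ring compounds. Nothing available explains why chain and rings read alike here.

Still open, from the compounds shown here alone, is how an amine, or a longer chain ending in a carboxylic acid, would read on this carbonyl carbon. Going by these compounds, an ethyl ester in place of the carboxylic acid is equally open.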